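A few compounds are considered here, and "the series" means these few. Any claim that something is new, unique, unknown or untested is made for them only; others in the source may bear on it.

Measured compounds:
- compound 1, `O=S(=O)(NCCCNCc1ccc(Cl)cc1)c1cc(C(F)(F)F)cc(C(F)(F)F)c1`: 2900 nM
- compound 2, `COc1cccc(CNCCCNS(=O)(=O)c2cc(C(F)(F)F)cc(C(F)(F)F)c2)c1`: 4500 nM
- compound 3, `O=S(=O)(NCCCNCC1COc2ccccc2O1)c1cc(C(F)(F)F)cc(C(F)(F)F)c1`: 2800 nM

All three share one core and differ only in the aryl group on the saturated chain carbon bound to the amine nitrogen. In a functional assay on BE(2)-C cells (Homo sapiens) for inhibition, read by MTT assay, with a stated time of 72 h (a lower number here means a stronger inhibitor of growth, a higher number a weaker inhibitor of growth), compound 1 stands second highest of the three numbers, with compound 3 nearest a 1.0-fold lower number from compound 1 to compound 3 (0.02 log units; within the scatter) and compound 2 furthest a 1.6-fold higher number from compound 1 to compound 2 (0.19 log units; within the scatter); the remaining pair also lies close together a 1.6-fold lower number from compound 2 to compound 3 (0.21 log units; within the scatter). None of the three steps goes beyond the scatter.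

Compound 4, `O=S(=O)(NCCCNCc1ccc(-c2ccccc2)cc1)c1cc(C(F)(F)F)cc(C(F)(F)F)c1`, keeps the chain and the sulfonamide of compound 1 and is changed at the far ring: phenyl in place of chloro on an aromatic carbon, on an aromatic carbon, para to a large group. No measured step touches this position, so nothing shown speaks directly for or against the change. Given that every exchange of the aryl group so far left the number within scatter, no step beyond the scatter is expected here either; compound 4 is expected at 2500 nM, range 800 nM to 8000 nM, a step of a 1.2-fold lower number from compound 1 to compound 4 (0.06 log units; within the scatter).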

Compound 4, concentration for 50% growth inhibition: 2600 nM
Compound 4: the middle estimate sits 1.0-fold (0.02 log units) below what was measured; low and high end bracket the measured number.
By their numbers in this assay, from the lowest: compounds 4, 3, 1 and 2 (each within the scatter of the next).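

Within the data shown here, at the aromatic carbon para to a large group, the exchange of phenyl in place of chloro gives a 1.1-fold lower number from compound 1 to compound 4 (0.05 log units; within the scatter) in this assay and so provides the first reading at this position. Six heavy atoms and a six-membered aromatic ring of carbon only enter where one chlorine stood, yet this step does not go beyond the scatter. Nothing available accounts for this result.

The compounds shown leave open whether a carboxylic acid or an amine at this position would also stay within the scatter of compound 1, since phenyl and chloro are the only groups compared here. They also leave open what a longer chain in place of the present one, or nitrile in place of trifluoromethyl, would do to the number.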